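The source may report more compounds than this note shows. Statements on the series, on what has been measured and on what is new or still open speak of the compounds shown alone.

Compound 3 `CN(c1ncccc1CNc1nc(Nc2ccc(F)c(Cl)c2)nc2[nH]cc(F)c12)S(C)(=O)=O` was tested in a functional assay on SMMC-7721 cells (Homo sapiens) for inhibition, read by MTT assay, with a stated time of 48 h; a lower number here means a stronger inhibitor, a higher number a weaker inhibitor. In this assay compound 3 gives > 100000 nM, which is a limit of the assay rather than a measured number. Compound 1 `Cc1cc2c(NCc3cccnc3N(C)S(C)(=O)=O)nc(Nc3ccc4c(c3)CC(=O)N4)nc2[nH]1` gives > 100000 nM in this assay, again only a limit. Compound 2 `CN(c1ncccc1CNc1nc(Nc2ccc3c(c2)CC(=O)N3)nc2[nH]cc(C#N)c12)S(C)(=O)=O` likewise reaches only a limit, > 100000 nM. All three values sit at the same ceiling, as the limit of > 100000 nM in this assay, at which 3 of the 3 values shown sit, records, so compound 3 cannot be placed above or below the other two on the numbers shown.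

Compound 4 `COc1cccc(Nc2nc(NCc3cccnc3N(C)S(C)(=O)=O)c3c(F)c[nH]c3n2)c1C` has not been measured yet. It differs from compound 3 in one place: 3-methoxy-2-methylphenyl in place of 3-chloro-4-fluorophenyl on a nitrogen on an aromatic ring. For the measured compounds named here, no step between two measured compounds exists, and three limits give no direction to work from. The step from compound 3 to compound 4 is therefore expected to be a number no higher from compound 3 to compound 4 (the limit leaves the size open), none beyond the scatter. Compound 4 is estimated at 100000 nM, within a range from 30000 nM to 300000 nM, and most probably this assay will again report only a limit for compound 4.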

Compound 4, half-maximal inhibitory concentration: > 100000 nM
Compound 4 was reported as a limit; the forecaster's own chance of this, stated with the estimate: 70%; the middle value sits exactly at the limit.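

In this assay, for the compounds shown here, no step from compound 3 to compound 4 can be read, because both compounds are reported only as limits: the limit of > 100000 nM in this assay, at which 4 of the 4 values shown sit. The compounds shown leave open how the four truly rank against one another, and whether any change to the shared core would give a measurable value.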